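This account rests on a few compounds, and the source may have more. Where it says the series, first, only, none or still open, it means among the compounds named here.

In a toxicity assay on HT-29 cells (Homo sapiens) for cytotoxicity (a lower number here means that less compound is tolerated, a higher number that more compound is tolerated), two compounds sharing one core have been measured so far. Compound 1 `CN1C(=S)[C@@H](NC(=O)c2nc(Cc3ccccc3)n(CCCF)n2)COc2ccccc21` gives > 100000 nM, which is a limit of the assay and not a number. Compound 2 `CN1C(=S)[C@@H](NC(=O)c2nc(Cc3ccccc3)n(CCCO)n2)COc2ccccc21` gives > 100000 nM, which is also a limit and not a number. The evidence therefore consists of the limit of > 100000 nM in this assay, at which 2 of the 2 values shown sit.

Compound 3 `CN1C(=S)[C@@H](NC(=O)c2nc(Cc3ccccc3)n(CCCC#N)n2)COc2ccccc21` differs from compound 2 at the end of the chain: cyano in place of hydroxy on a saturated chain carbon, three bonds along the chain from an aromatic nitrogen. This places cyano in place of hydroxy on a saturated chain carbon, three bonds along the chain from an aromatic nitrogen. For the measured compounds named here, the one measured step at this place is a step that the two limits leave unreadable from compound 1 to compound 2, so it offers no size to carry over. The expectation instead rests on compound 2, whose reading of > 100000 nM is a limit with no measured number behind it. The expected step, a number no higher from compound 2 to compound 3 (the limit leaves the size open), is none beyond the scatter in this assay, and no direction is favoured. Compound 3 is estimated at 100000 nM, with an expected range from 40000 nM to 150000 nM, and the assay may well report only a limit again.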

Compound 3, half-maximal cytotoxic concentration: > 100000 nM
Compound 3 was reported as a limit; the forecaster's own chance of this, stated with the estimate: 85%; the middle value lies on the limit itself.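

In this assay compound 3 gives > 100000 nM, which is again a limit and not a number. For the compounds shown here, no step among compound 1, compound 2 and compound 3 can be read from these limits. The compounds shown leave open whether these three differ at all in this assay, and what half-maximal cytotoxic concentration any of them actually has.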